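The compounds below may be only part of what the source reports. "The series", "measured", "known", "first", "only" and "open" are said of these compounds alone.

Compound 1 `N#CC1=C(NC(=O)C2CC2)N(c2ccc(S(N)(=O)=O)cc2)C2=C(C(=O)CCC2)C1c1ccc(Cl)cc1Cl` gives the largest of the three numbers seen so far in a functional assay on Ehrlich cells (Mus musculus) for cytotoxicity, read by trypan blue exclusion, with a stated time of 2 h, tested at 25 ug/mL (on this read-out lower numbers stand for a weaker effect and higher numbers for a stronger effect at the one concentration tested), with compound 1 at 40%, though both other compounds lie within the scatter of it. Compound 2 `Cc1ccc(C(=O)NC2=C(C#N)C(c3ccc(Cl)cc3Cl)C3=C(CCCC3=O)N2c2ccc(S(N)(=O)=O)cc2)cc1` gives 30% in this assay, and compound 3 `CN(C)c1ccc(/C=N/C2=C(C#N)C(c3ccc(Cl)cc3Cl)C3=C(CCCC3=O)N2c2ccc(S(N)(=O)=O)cc2)cc1` gives 30% in this assay.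

Compound 4 `CCO/C=N/C1=C(C#N)C(c2ccc(Cl)cc2Cl)C2=C(CCCC2=O)N1c1ccc(S(N)(=O)=O)cc1` differs from compound 1 in a group of 5 heavy atoms (3 carbon, 1 nitrogen, 1 oxygen; no ring) in place of a group of 6 heavy atoms (4 carbon, 1 nitrogen, 1 oxygen; one three-membered non-aromatic ring of carbon only), on a double-bonded ring carbon. The two measured steps at the same double-bonded ring carbon bear on this: a number 10 percentage points lower from compound 1 to compound 2 (within the scatter) and a number 10 percentage points lower from compound 1 to compound 3 (within the scatter), each within the scatter, so the (cyclopropylcarbonyl)amino group has not shown itself decisive here. No step beyond the scatter is therefore expected for a number 7 percentage points lower from compound 1 to compound 4 (within the scatter). Compound 4 is estimated at 33%, with a range from 20% to 46%.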

Compound 4, a percentage reported as activity, at one concentration (the size of the read-out at that concentration, not a potency): 30%
Compound 4: middle estimate off by 3 percentage points, on the high side; the measured number falls inside the stated range.
By their numbers in this assay, from the lowest: compounds 2, 3, 4 and 1 (each within the scatter of the next).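

At this double-bonded ring carbon, a group with no ring and no hydrogen-bond donor still gives no step beyond the scatter in this assay: a number 10 percentage points lower from compound 1 to compound 4 (within the scatter) and no change at the digits printed from compound 2 to compound 4 (within the scatter). Ethoxy in place of 4-(dimethylamino)phenyl on the carbon with a double bond to nitrogen gives no change at the digits printed from compound 3 to compound 4 (within the scatter). No supporting data bear on why these groups are so alike here.

From the compounds shown here alone, whether an amine, a carboxylic acid or a longer alkyl chain at this carbon would move the number beyond the scatter remains open. Also open, going by these compounds, is how the 2,4-dichlorophenyl group bears on this read-out.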